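The source may report more compounds than this note shows. Statements on the series, on what has been measured and on what is new or still open speak of the compounds shown alone.

Series notes: aromatic esters bearing a 2-carboxyethenyl arm, compared in a functional assay on EA.hy 926 cells (Homo sapiens) for cytotoxicity, read by MTT assay, with stated times of 24 h and 12 h, tested at 50 uM; on this read-out higher numbers stand for a stronger effect at the one concentration tested and lower numbers for a weaker effect.

Compound 1 `COc1cc(/C=C/C(=O)O)ccc1OC(=O)c1nc(C)c(C)nc1C` gives 49.1% in this assay. Compound 2 `CCOC(=O)/C=C/c1ccc(OC(=O)c2nc(C)c(C)nc2C)c(O)c1` gives 211% in this assay. Compound 3 `Cc1nc(C)c(C(=O)Oc2ccc(/C=C/C(=O)O)cc2)nc1C` gives 74.1% in this assay, the second highest of the three numbers; the step of a number 25 percentage points higher from compound 1 to compound 3 (beyond the scatter) is modest yet beyond the scatter, and compound 2 sits far higher.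

Compound 4 `Cc1nc(C)c(C(=O)Oc2ccc(/C=C/C(=O)O)cc2O)nc1C` differs from compound 3 by hydroxy in place of hydrogen on an aromatic carbon. Within the data shown here, no measured step concerns a hydroxy entering at this place, and compound 2 differs from compound 4 in more than one place, so no step is drawn from it. Among the measured compounds shown here, the one step that is measured is on a different carbon and does not bear directly. A step of a number 20.9 percentage points higher from compound 3 to compound 4 (beyond the scatter) is expected, leaving compound 4 estimated at 95%, within 50% to 170%.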

Compound 4, a percentage reported as activity, at one concentration (the size of the read-out at that concentration, not a potency): 285%
Estimate against measurement, compound 4: 190 percentage points below, and the stated range ends below it.
By their numbers in this assay, from the lowest: compound 1; then compound 3; then compound 2; then compound 4.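

In this assay this aromatic carbon, ortho to a large group, responds strongly to hydroxy, with a number 210.9 percentage points higher from compound 3 to compound 4 (beyond the scatter) as the step for hydroxy in place of hydrogen. The free hydroxy and free acid both count here: a number 235.9 percentage points higher from compound 1 to compound 4 (beyond the scatter) comes with hydrogen in place of methyl on the oxygen on the aromatic ring, and a number 74 percentage points higher from compound 2 to compound 4 (beyond the scatter) with hydrogen in place of ethyl on the oxygen next to a carbonyl group, leaving compound 4 highest of the four. Nothing available explains these steps.

Open, as far as these compounds go, is how an amine at this carbon would compare, and whether a longer chain on either oxygen would lower the number further.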